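The source may report more compounds than this note shows. Statements on the series, on what has been measured and on what is new or still open speak of the compounds shown alone.

Measured in an ADME assay on BaF3 cells (Mus musculus) for cytotoxicity; on this read-out lower numbers stand for an effect already at smaller amounts and higher numbers for an effect only at larger amounts of compound:
Compound 1, `CN1CCN(C(=O)c2cc3c(Nc4ccc(OC(F)(F)F)cc4)ncnc3s2)CC1`: 2690 nM
Compound 2, `CC(C)(C)n1ncc2c(Nc3ccc(OC(F)(F)F)cc3)ncnc21`: 7300 nM
Compound 3, `OCCn1cc2c(Nc3ccc(OC(F)(F)F)cc3)ncnc2n1`: > 10000 nM

The value of compound 3 is a limit of this assay and not a number; it is the limit of > 10000 nM in this assay, at which 1 of the 3 values shown sits. Among the two numbers, compound 2 stands highest, and compound 1 sits a step under it that goes beyond the scatter. Compound 4, `FC(F)(F)Oc1ccc(Nc2ncnc3c2cnn3Cc2ccccc2)cc1`, has not yet been measured. It differs from compound 2 by benzyl in place of tert-butyl on an aromatic nitrogen. No comparable step has been measured among these compounds, so the direction of this change is open, and the account expects no step beyond the scatter. Compound 4 is estimated at 6000 nM, within 2500 nM to 15000 nM. That estimate means an expected step of a 1.2-fold lower number from compound 2 to compound 4 (0.09 log units; within the scatter), with a fair chance that only a limit is reported.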

Compound 4, half-maximal effective concentration: > 10000 nM
Compound 4 gave a limit, no number (the forecaster's own chance of this, stated with the estimate: 30%); at least 1.6-fold (0.22 log units) between middle value and limit.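

In this assay, benzyl in place of tert-butyl on an aromatic nitrogen gives an at least 1.3-fold higher number from compound 2 to compound 4 (0.13 log units; that floor lies within the scatter), the first step read at this position. The larger group with its six-membered aromatic ring therefore brings no effect at smaller amounts of compound. Compound 4 gives a limit and not a number, so the step has only a floor: the limit of > 10000 nM in this assay, at which 2 of the 4 values shown sit.

From the compounds shown here alone, how far compound 4 truly lies from compound 2 stays open. So does what an amine or a carboxylic acid on this nitrogen would do in this assay.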